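Swapping chloro for hydroxy on one aromatic carbon

The compounds below may be only part of what the source reports. "The series", "measured", "known", "first", "only" and "open" are said of these compounds alone.

- Compound 1 `O=C1CC(N2C(=O)CSC2=S)C(=O)N1c1ccc(O)cc1`: > 100000 nM (a limit, not a number)
- Compound 2 `O=C1CC(N2C(=O)/C(=C/C(Cl)=C/c3ccc([N+](=O)[O-])cc3)SC2=S)C(=O)N1c1ccc(Cl)cc1`: 9180 nM

Both entries come from a functional assay on HCT-116 cells (Homo sapiens) for inhibition, read by MTT assay, with a stated time of 72 h; on this read-out higher numbers stand for weaker inhibition of growth and lower numbers for stronger inhibition of growth. Compound 1 reads > 100000 nM, and this is a limit of the assay rather than a measured number. In this assay, within the data shown here, compound 2 gives 9180 nM, which makes it the only compound with a true number so far.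

The next compound to be tested is compound 3 `O=C1CC(N2C(=O)/C(=C/C(Cl)=C/c3ccc([N+](=O)[O-])cc3)SC2=S)C(=O)N1c1ccc(O)cc1`. It matches compound 2 except in one place, where 4-chlorophenyl becomes 4-hydroxyphenyl: hydroxy in place of chloro on an aromatic carbon, para to a large group (hydroxy in place of chloro on an aromatic carbon).

Among the measured compounds shown here, no measured pair shows this change on its own, so the data cannot give its size directly. The best anchor is compound 2 at 9180 nM, and a small shift towards weaker inhibition in this assay is expected, perhaps no larger than the usual scatter. The expected change is a 1.3-fold higher number from compound 2 to compound 3 (0.12 log units; within the scatter). Compound 3 is estimated at 12000 nM, with an expected range of 4000 nM to 40000 nM.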

Compound 3, concentration for 50% growth inhibition: 4520 nM
For compound 3 the middle estimate is 2.7-fold (0.42 log units) above the measured one; measured number inside the range.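

In this assay, among these compounds, the first direct comparison at this position comes from two compounds that are otherwise identical: hydroxy in place of chloro on the aromatic carbon gives a 2.0-fold lower number from compound 2 to compound 3 (0.31 log units; beyond the scatter). The step is modest, but it lies beyond the usual scatter and points to stronger inhibition of growth, so this position tolerates the swap from 4-chlorophenyl to 4-hydroxyphenyl, which brings in a hydrogen-bond donor and acceptor, without any loss on this read-out. Nothing measured here explains why the number falls with this change.

On these data alone, this single pair cannot show whether the gain belongs to hydroxy itself, and how a methoxy group or an amine at the same place would compare remains open, as does whether the same step would appear with a different rest of the molecule. Compound 1 also carries the 4-hydroxyphenyl group, but it reads > 100000 nM, which is a limit and not a number, so steps involving it cannot be read.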